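Dichloroacetamides on a biphenyl core: a methyl replacement

A few compounds are considered here, and "the series" means these few. Any claim that something is new, unique, unknown or untested is made for them only; others in the source may bear on it.

Compound 1 `O=C(Nc1cccc(-c2ccsc2)c1)C(Cl)Cl`: > 50000 nM
Compound 2 `O=C(Nc1cccc(-c2cccc(NC(=O)C(Cl)Cl)c2)c1)C(Cl)Cl`: > 50000 nM
Compound 3 `CC(C)c1ccc(-c2cc(NC(=O)C(Cl)Cl)cc(-c3ccc(C(C)C)cc3)c2)cc1`: > 30000 nM

In a functional assay on KB 3-1 cells (Homo sapiens) for cytotoxicity, read by MTT assay, with a stated time of 68 h (on this read-out higher numbers stand for weaker inhibition and lower numbers for stronger inhibition), compound 1 gives only a limit, > 50000 nM. Compound 2 likewise reaches only a limit in this assay, > 50000 nM, so no number is known for it. Compound 3 gives a limit as well, > 30000 nM. Among the measured compounds shown here, all three values shown are thus limits, two of them at the limit of > 50000 nM in this assay, at which 2 of the 3 values shown sit, and one at the limit of > 30000 nM in this assay, at which 1 of the 3 values shown sits, and no step between measured compounds is available.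

Compound 4 `Cc1cccc(-c2cccc(NC(=O)C(Cl)Cl)c2)c1` differs from compound 2 in one place: methyl in place of ((dichloromethyl)carbonyl)amino on an aromatic carbon. With every measured compound sitting at a limit, no step beyond the scatter is expected, a number no higher from compound 2 to compound 4 (the limit leaves the size open). Compound 4 is therefore expected to give about 50000 nM in this assay, within 20000 nM to 100000 nM, most likely reported only as a limit.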

Compound 4, half-maximal inhibitory concentration: > 50000 nM
Compound 4 gave a limit, no number (the forecaster's own chance of this, stated with the estimate: 85%); the middle value lies on the limit itself.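

Among the compounds shown here, compound 2 and compound 4 both give only a limit, so no step between them can be read. The compounds shown leave open what actual number any of them would reach in this assay.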